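Amide nitrogen substituent in the shared series

This account rests on a few compounds, and the source may have more. Where it says the series, first, only, none or still open, it means among the compounds named here.

Compound 3 `CC(NC(=O)/C=C/c1ccc(NC(=O)Nc2ccc(Cl)c(C(F)(F)F)c2)cc1)c1ccccc1` gives 12200 nM in a functional assay on HepG2 cells (Homo sapiens) for inhibition, read by MTT assay, with a stated time of 120 h; a higher number here means a weaker inhibitor, a lower number a stronger inhibitor. Among the numbers shown it stands highest of two, its nearest neighbour being compound 2 `O=C(/C=C/c1ccc(NC(=O)Nc2ccc(Cl)c(C(F)(F)F)c2)cc1)NC1CCC1`, which in this assay gives 7510 nM; the step of a 1.6-fold higher number from compound 2 to compound 3 (0.21 log units; within the scatter) sits within the scatter. Compound 1 `C/C(=C\c1ccc(NC(=O)Nc2ccc(Cl)c(C(F)(F)F)c2)cc1)C(=O)NC(C)c1ccccc1` is known in this assay only as a limit, > 50000 nM, and the limit of > 50000 nM in this assay, at which 1 of the 3 values shown sits, records it as such.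

Compound 4 `CNC(=O)/C=C/c1ccc(NC(=O)Nc2ccc(Cl)c(C(F)(F)F)c2)cc1` differs from compound 3 in one place: methyl in place of 1-phenylethyl on an amide-type nitrogen. Among the measured compounds shown here, the only measured step on the same nitrogen is a 1.6-fold higher number from compound 2 to compound 3 (0.21 log units; within the scatter), which in the reverse direction trimmed the substituent from 1-phenylethyl to cyclobutyl and moved the number only within the scatter. Going further to methyl is a larger cut, and no measured pair covers it; the expectation is therefore a small step, if any, toward a lower number. Compound 4 is expected at 8000 nM, within 2500 nM to 30000 nM. The estimated step of a 1.5-fold lower number from compound 3 to compound 4 (0.18 log units; within the scatter) is expected to stay close to the scatter.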

Compound 4, half-maximal inhibitory concentration: 20400 nM
The estimate for compound 4 lay 2.6-fold (0.41 log units) below the measured number; the range from low to high includes it.
By their numbers in this assay, from the lowest: compounds 2, 3 and 4 (each within the scatter of the next, the first and the last beyond it). At a limit, above all of these: compound 1.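

In this assay, the much larger cut from 1-phenylethyl to methyl on the amide-type nitrogen gives a 1.7-fold higher number from compound 3 to compound 4 (0.22 log units; within the scatter), so removing the aromatic ring from this substituent produces no step beyond the scatter. Against cyclobutyl, the same methyl gives a 2.7-fold higher number from compound 2 to compound 4 (0.43 log units; beyond the scatter), the first step at this nitrogen to pass the scatter, though only a modest one. Nothing shown gives a cause for either step.

On these data alone, whether a longer chain ending in an amine or a carboxylic acid on this nitrogen would bring the number under that of compound 2 remains open. Compound 1 is known only as a limit (> 50000 nM), so the effect of its extra methyl on the shared core cannot be sized.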